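Replacing 3-methoxyphenyl with 2,5-dimethylphenyl in compound 2

This account rests on a few compounds, and the source may have more. Where it says the series, first, only, none or still open, it means among the compounds named here.

Compound 1 `COc1ccc(-c2nc(C)oc2C(=O)N2CCN(c3cccc(Cl)c3)CC2)cc1OC` gives "not active" (no number reported)
Compound 2 `COc1cccc(N2CCN(C(=O)c3oc(C)nc3-c3ccccc3F)CC2)c1` gives 56.1 nM
Compound 3 `CCc1nc(-c2ccc(F)cc2)c(C(=O)N2CCN(c3cccc(Cl)c3)CC2)o1` gives 169 nM

These three compounds were tested in a functional assay on HL-60 cells (Homo sapiens) for inhibition, read by MTT assay, with a stated time of 72 h (a lower number here means a stronger inhibitor, a higher number a weaker inhibitor), and are compared by their half-maximal inhibitory concentration. Compound 2 gives 56.1 nM as the lower of the two numbers, while compound 3 gives 169 nM and the gap between them lies beyond the usual scatter. Compound 1 yields no number.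

Compound 4 `Cc1ccc(C)c(N2CCN(C(=O)c3oc(C)nc3-c3ccccc3F)CC2)c1` has not yet been measured. Its difference from compound 2 2,5-dimethylphenyl in place of 3-methoxyphenyl on an amine nitrogen in a ring is a single exchange: 2,5-dimethylphenyl in place of 3-methoxyphenyl on an amine nitrogen in a ring. Within the data shown here, no two measured compounds differ in only one place, so the data give no direct size for this exchange. In this assay a moderate rise in the number is expected, since compound 2 with 56.1 nM already holds the lowest number and compound 3 with 169 nM lies higher. The expected step is a 2.1-fold higher number from compound 2 to compound 4 (0.33 log units; beyond the scatter) and it remains an estimate with wide uncertainty. For compound 4 the estimated value is 120 nM with an expected range from 35 nM to 450 nM in this measurement.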

Compound 4, half-maximal inhibitory concentration: 319 nM
Estimate against measurement, compound 4: 2.7-fold (0.42 log units) below, and the stated range covers the measured number.
By their numbers in this assay, from the lowest: compound 2; then compounds 3 and 4 (each within the scatter of the next).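

The aryl group on the ring amine nitrogen now has its first measured exchange, and with the rest of the molecule unchanged, the step in this assay is a 5.7-fold higher number from compound 2 to compound 4 (0.75 log units; beyond the scatter). This position therefore responds to a change of aryl group, even though 3-methoxyphenyl and 2,5-dimethylphenyl both have 8 heavy atoms and one six-membered aromatic ring of carbon only, and differ in that the first has 1 hydrogen-bond acceptor and the second has 0. Compound 4 still gives a number, 319 nM, so this exchange weakens inhibition without abolishing it, though nothing shown explains the rise.

Among these compounds, the single step changes the methoxy group and both methyl groups at once, so it cannot say which of these accounts for the rise; a phenyl ring bearing one methyl group or one hydroxyl group would be needed to separate them. It also rests on one pair of compounds, which leaves open whether the same exchange would move the number by a similar amount with a different group on the rest of the molecule, such as a 3-chlorophenyl on the ring amine nitrogen paired with a longer chain elsewhere.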